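Amide to urea on the dichlorophenyl arm of the series

This account rests on a few compounds, and the source may have more. Where it says the series, first, only, none or still open, it means among the compounds named here.

Two compounds of the series have numbers in a functional assay on SF-295 cells (Homo sapiens) for inhibition, read by sulforhodamine B assay, with a stated time of 48 h, tested at 10 uM (on this read-out higher numbers stand for a weaker effect at the one concentration tested and lower numbers for a stronger effect), so far. Compound 1 `COc1cc(Cl)cc(-c2nn(-c3cccc(NC(=O)c4cc(C(F)(F)F)cc(C(F)(F)F)c4)c3)cc2-c2ccncc2)c1` gives 42.1%, and compound 2 `COc1cc(Cl)cc(-c2nn(-c3cccc(NC(=O)c4ccc(Cl)c(Cl)c4)c3)cc2-c2ccncc2)c1` gives 36.1%, a gap that lies within the scatter, so the two read alike. Compound 3 `COc1cc(Cl)cc(-c2nn(-c3cccc(NC(=O)Nc4ccc(Cl)c(Cl)c4)c3)cc2-c2ccncc2)c1` carries the change ((3,4-dichlorophenyl)amino in place of 3,4-dichlorophenyl on a carbonyl carbon). For the measured compounds named here, no measured step covers such a change here, so the expectation rests on the shared core and on compound 2 alone. Compound 3 is expected to stay close to compound 2, with a step of a number 1.9 percentage points higher from compound 2 to compound 3 (within the scatter), not beyond the scatter. The estimate for compound 3 is 38%, ranging from 20% to 60%.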

Compound 3, a percentage reported as activity, at one concentration (the size of the read-out at that concentration, not a potency): -2.42%
Beside the measured number, compound 3's estimate is 40.4 percentage points above it; measured number below the stated range.
By their numbers in this assay, from the lowest: compound 3; then compounds 2 and 1 (each within the scatter of the next).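

In this assay, the amide-to-urea change on this arm is far from neutral: (3,4-dichlorophenyl)amino in place of 3,4-dichlorophenyl on a carbonyl carbon gives a number 38.5 percentage points lower from compound 2 to compound 3 (beyond the scatter) and so marks this position as sensitive, which the two amides, compound 1 and compound 2, did not show. No measurement here accounts for this step.

Still open, from the compounds shown here alone, is whether the step depends on the entering amino nitrogen, which a carbamate oxygen or a methylene group in its place would test. Also open, going by these compounds, is whether the urea gives a similar step with the bis(trifluoromethyl)phenyl group of compound 1.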